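Dichlorophenyl in place of hydroxyphenyl: a step from a limit

The source may hold more compounds than are shown below. What is called first, only, known or untested is meant among the compounds shown, and "the series" means these compounds.

Measured so far in a functional assay on HT-1080 cells (Homo sapiens) for cytotoxicity, read by MTT assay, with a stated time of 72 h; on this read-out lower numbers stand for stronger inhibition and higher numbers for weaker inhibition:
- compound 1 `COc1cccc(/C=C2\CCC/C(=C\c3ccc(Cl)cc3)C2=O)c1OC` gives 11100 nM
- compound 2 `COc1cccc(/C=C2\CCC/C(=C\c3ccccc3Br)C2=O)c1OC` gives 10800 nM
- compound 3 `COc1cccc(/C=C2\CCC/C(=C\c3ccc(O)cc3)C2=O)c1OC` gives > 20000 nM as a limit

Compound 3 has no number, only the limit of > 20000 nM in this assay, at which 1 of the 3 values shown sits, and so its place is open on the upper side. Compound 4 `COc1cccc(/C=C2\CCC/C(=C\c3cccc(Cl)c3Cl)C2=O)c1OC` carries 2,3-dichlorophenyl in place of 4-hydroxyphenyl on a double-bonded chain carbon bound to a double-bonded ring carbon.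

Among the compounds with values here, three measured steps bear on this change. The step between the two halogen-bearing phenyl groups is a 1.0-fold lower number from compound 1 to compound 2 (0.01 log units; within the scatter) and shows no change. The steps to the hydroxy compound are an at least 1.8-fold higher number from compound 1 to compound 3 (0.25 log units; that floor lies within the scatter) and an at least 1.8-fold higher number from compound 2 to compound 3 (0.26 log units; that floor lies within the scatter) and both are floors only.

Compound 4 also bears halogen, so it is expected to sit near compound 1 at 11100 nM and compound 2 at 10800 nM in this assay. The expected move is an at least 2.1-fold lower number from compound 3 to compound 4 (0.32 log units; beyond the scatter) and points to a lower number. For compound 4 the estimated value is 9500 nM with an expected range of 4500 nM to 20000 nM.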

Compound 4, half-maximal inhibitory concentration: 19300 nM
Compound 4: middle estimate off by 2.0-fold (0.31 log units), on the low side; measured number inside the range.
By their numbers in this assay, from the lowest: compounds 2, 1 and 4 (each within the scatter of the next). At a limit, above all of these: compound 3.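

In this assay the 2,3-dichlorophenyl group on a double-bonded chain carbon bound to a double-bonded ring carbon does not separate from the earlier halogen-bearing groups, with a 1.8-fold higher number from compound 2 to compound 4 (0.25 log units; within the scatter) and a 1.7-fold higher number from compound 1 to compound 4 (0.24 log units; within the scatter) as the steps. Across compounds 1, 2 and 4, changing the halogen-bearing phenyl group therefore leaves the numbers within the scatter, and the step from the 4-hydroxyphenyl group, an at least 1.0-fold lower number from compound 3 to compound 4 (0.01 log units; that floor lies within the scatter), is only a floor and does not show a real gain. Compound 3 remains without a number: the limit of > 20000 nM in this assay, at which 1 of the 4 values shown sits.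

Where compound 3 truly lies stays open, so the effect of the hydroxy group cannot be sized. Also open, as far as these compounds go, is whether an amine or a carboxylic acid on this phenyl group would move the number beyond the scatter from compounds 1, 2 and 4.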